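Chloro for Fluoro on a Fused Sulfonyl Core

A few compounds are considered here, and "the series" means these few. Any claim that something is new, unique, unknown or untested is made for them only; others in the source may bear on it.

Compound 1, `CCNC1=NS(=O)(=O)c2cc(F)ccc2N1`, in a functional assay (aorta) with Rattus norvegicus as the target; a higher number here means that more compound is needed for the effect, a lower number that less compound is needed: only a limit of the assay, > 300 uM.
Compound 2, `O=S1(=O)NC(NCC2CC2)=Nc2ccc(F)cc21`, in this assay: 146 uM.
Compound 3, `CCNC1=NS(=O)(=O)c2cc(Cl)ccc2N1`, in this assay: 39.9 uM.

Compounds 1 and 3 share one core and differ only by chloro in place of fluoro on an aromatic carbon; that change gave an at least 7.5-fold lower number from compound 1 to compound 3 (0.87 log units; beyond the scatter). Compound 1 sits at the limit of > 300 uM in this assay, at which 1 of the 3 values shown sits, so the full size of that step is not pinned down. Compound 2 carries a different core, and how the two cores differ is not broken down here. Compound 4, `O=S1(=O)NC(NCC2CC2)=Nc2ccc(Cl)cc21`, is not yet measured in this assay; it differs from compound 2 by chloro in place of fluoro on an aromatic carbon, the same change as before. The change is expected to give a 5.8-fold lower number from compound 2 to compound 4 (0.77 log units; beyond the scatter) because an at least 7.5-fold lower number from compound 1 to compound 3 (0.87 log units; beyond the scatter) was seen with the other core. Compound 4 is therefore estimated at 25 uM, with a likely range from 8 uM to 80 uM.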

Compound 4, concentration for half-maximal effect: 41.2 uM
Estimate against measurement, compound 4: 1.6-fold (0.22 log units) below; low and high end bracket the measured number.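

Chloro in place of fluoro on an aromatic carbon gave a 3.5-fold lower number from compound 2 to compound 4 (0.55 log units; beyond the scatter) in this assay and so pointed the same way on both cores. This shows that the direction of the change carried over between these two cores, but two cores do not show that it will hold on others. Whether the size of the step carried over is unsettled: the same change on two cores in this assay, an at least 7.5-fold lower number (0.87 log units; beyond the scatter) from compound 1 to compound 3 and a 3.5-fold lower number (0.55 log units; beyond the scatter) from compound 2 to compound 4; the limit leaves it open whether they differ.

The compounds shown leave open how bromo, methoxy or a nitrile would compare with chloro on that aromatic carbon. They also leave open how a longer chain or a carboxylic acid would compare with the ethyl and cyclopropylmethyl groups on the amine.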